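Replacing a hydroxy-methoxy ring with a fluorophenyl ring

A few compounds are considered here, and "the series" means these few. Any claim that something is new, unique, unknown or untested is made for them only; others in the source may bear on it.

Measured compounds in an in vitro ADME assay on microsomes from liver (Homo sapiens) for metabolic stability; on this read-out lower numbers stand for slow clearance and higher numbers for fast clearance:
- compound 1 `O=C(C=C1CCN(C(=O)c2ccc(F)cc2)CC1)N[C@@H]1CCN(Cc2ccc3cc(F)ccc3c2)C1` gives 237 mL/min/kg
- compound 2 `COc1cccc(C(=O)N2CCC(=CC(=O)N[C@@H]3CCN(Cc4ccc5cc(F)ccc5c4)C3)CC2)c1` gives 500 mL/min/kg
- compound 3 `COc1cccc(O)c1C(=O)N1CCC(=CC(=O)N[C@@H]2CCN(Cc3ccc4cc(F)ccc4c3)C2)CC1` gives 192 mL/min/kg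

Compound 3 has the lowest number of the three. Its distance to compound 1 is small: a 1.2-fold lower number from compound 1 to compound 3 (0.09 log units; within the scatter), so the two cannot be told apart. Its distance to compound 2 is real: a 2.6-fold lower number from compound 2 to compound 3 (0.42 log units; beyond the scatter).

Compound 4 `O=C(C=C1CCN(C(=O)c2cccc(F)c2)CC1)N[C@@H]1CCN(Cc2ccc3cc(F)ccc3c2)C1` has not yet been measured in this assay. It differs from compound 3 in one place: 3-fluorophenyl in place of 2-hydroxy-6-methoxyphenyl on a carbonyl carbon.

For the measured compounds named here, two measured steps bear on this change. The step from compound 1 to compound 3 put the 2-hydroxy-6-methoxyphenyl group in place of a fluorophenyl group and changed nothing beyond the scatter; compound 4 carries a fluorophenyl group again, with the fluorine at a different position in the ring. The step from compound 1 to compound 2, a 2.1-fold higher number from compound 1 to compound 2 (0.32 log units; beyond the scatter), shows that moving to a 3-methoxyphenyl group did raise the number, so a substituent at that ring position is not without effect here.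

On this basis compound 4 is expected to land near compound 1, with a small rise expected from compound 3: a 1.3-fold higher number from compound 3 to compound 4 (0.11 log units; within the scatter). The estimate for compound 4 is 250 mL/min/kg, in the range 130 mL/min/kg to 480 mL/min/kg.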

Compound 4, clearance: 459 mL/min/kg
Beside the measured number, compound 4's estimate is 1.8-fold (0.26 log units) below it, and the stated range covers the measured number.
By their numbers in this assay, from the lowest: compounds 3, 1, 4 and 2 (each within the scatter of the next, the first and the last beyond it).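

In this assay, the 3-fluorophenyl group does not keep the low number seen with the 2-hydroxy-6-methoxyphenyl group (a 2.4-fold higher number from compound 3 to compound 4 (0.38 log units; beyond the scatter)), so the ring on this carbonyl carbon can shift clearance by more than the usual scatter. Fluoro in place of methoxy on the aromatic carbon gives no readable change (a 1.1-fold lower number from compound 2 to compound 4 (0.04 log units; within the scatter)), and the 3-fluorophenyl and 4-fluorophenyl groups cannot be told apart either (a 1.9-fold higher number from compound 1 to compound 4 (0.29 log units; within the scatter)). Compound 2 and compound 4 therefore both stand clearly apart from compound 3, whereas compound 1 cannot be separated from compound 3 or from compound 4, which leaves compound 1 as the one that blurs any simple ranking of these rings. Nothing shown here gives a measured explanation for these differences in clearance.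

Going by these compounds, it remains open whether the hydroxy group, the methoxy group or the two together set compound 3 apart, a question that a phenyl ring carrying only one of them would help to settle. On these data alone, how this position would respond to a ring bearing an amine or a carboxylic acid also remains unknown.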